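The compounds below may be only part of what the source reports. "The series", "measured", "known", "first", "only" and "open" are said of these compounds alone.

Measured in a functional assay on THP-1 cells (Homo sapiens) for cytotoxicity, read by MTT assay, with a stated time of 72 h; a higher number here means a weaker inhibitor, a lower number a stronger inhibitor:
- Compound 1 `C=C1CC[C@H]2C(C)(C)CCC[C@]2(C)[C@H]1CCC(C)CC(=O)O`: 132000 nM
- Compound 2 `COc1ccc(/C=C2\CC[C@H]3C(C)(C)CCC[C@]3(C)[C@H]2CCC(C)CC(=O)O)cc1`: > 200000 nM, a limit
- Compound 3 `CC(CC[C@H]1/C(=C/c2ccc(F)cc2)CC[C@H]2C(C)(C)CCC[C@]12C)CC(=O)O`: > 200000 nM, a limit

Compound 3 has no exact number, only the limit > 200000 nM. Compound 4 `CC(CC[C@H]1/C(=C/c2ccc(I)cc2)CC[C@H]2C(C)(C)CCC[C@]12C)CC(=O)O` has iodo in place of fluoro on an aromatic carbon, para to a large group (iodo in place of fluoro on an aromatic carbon). Among the measured compounds shown here, the one measured step with a swap at this place is a step that the two limits leave unreadable from compound 2 to compound 3. The picture in this assay is set by the limit of > 200000 nM in this assay, at which 2 of the 3 values shown sit. No measured size or direction carries over, so no change beyond the scatter is expected. The expected move is a number no higher from compound 3 to compound 4 (the limit leaves the size open). Compound 4 is estimated at 200000 nM, within an expected range from 100000 nM to 400000 nM.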

Compound 4, half-maximal inhibitory concentration: 33000 nM
The estimate for compound 4 lay 6.1-fold (0.78 log units) above the measured number; the whole stated range lies above it.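

Iodo in place of fluoro gives an at least 6.0-fold lower number from compound 3 to compound 4 (0.78 log units; beyond the scatter) in this assay and iodo in place of methoxy gives an at least 6.0-fold lower number from compound 2 to compound 4 (0.78 log units; beyond the scatter) and so the group on this aromatic carbon, para to a large group, can move the read-out. Among the compounds shown here, the step between compound 2 and compound 3 cannot be read, so these are the first readable changes here. Both sizes are minimums, because the starting compounds carry only a limit: the limit of > 200000 nM in this assay, at which 2 of the 4 values shown sit.

Going by these compounds, whether bromo or chloro at this place would also lower the number stays open. So does the effect of an amine there.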